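A few compounds are considered here, and "the series" means these few. Any claim that something is new, unique, unknown or untested is made for them only; others in the source may bear on it.

For the measured compounds named here, in a functional assay on the whole organism with Mus musculus as the target (a lower number here means that less compound is needed, a higher number that more compound is needed for the effect), compound 1 `CC[C@@H](C(=O)NN)N1CCCC1=O` gives 1000 umol/kg, and compound 2 `CC[C@@H](C(=N)S)N1CCCC1=O` gives 1000 umol/kg, so compound 2 stands level with the only other compound measured. Going by the values given here, the single measured step available reads no change at the digits printed from compound 1 to compound 2 (within the scatter). That step replaced the group on a saturated chain carbon bound to an amide-type nitrogen in a ring and a saturated chain carbon.

The next compound, compound 3 `CC[C@@H](C(=N)N)N1CCCC1=O`, keeps the core of compound 2 and differs from it by amino in place of sulfanyl on a carbon with a double bond to nitrogen. Compound 3 thus carries amino where compound 2 carries sulfanyl. No measurement isolates this exchange, so the evidence is indirect and thin, resting on one pair of compounds. Among the compounds with values here, the only guide is that compound 2 showed no shift from compound 1, as seen in no change at the digits printed from compound 1 to compound 2 (within the scatter). An estimated step of no change at the digits printed from compound 2 to compound 3 (within the scatter) is therefore expected in this assay, which means none beyond the scatter. For compound 3 the expected value is 1000 umol/kg, with an estimated range from 400 umol/kg to 2200 umol/kg.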

Compound 3, dose for half-maximal effect: 1000 umol/kg
Compound 3: the middle estimate sits on the measured number at the digits printed; the measured number falls inside the stated range.
By their numbers in this assay, from the lowest: compounds 1, 2 and 3 (each within the scatter of the next).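

In this assay, amino in place of sulfanyl on a carbon with a double bond to nitrogen reads as no change at the digits printed from compound 2 to compound 3 (within the scatter) and so offers no separation between these two groups, which have the same counts of heavy atoms and hydrogen-bond donors and carry no net charge. Set against the group of compound 1, the group of 3 heavy atoms bearing amino reads as no change at the digits printed from compound 1 to compound 3 (within the scatter) in the same assay, so there are now two separate replacements of that group, and all three groups on the saturated chain carbon bound to an amide-type nitrogen in a ring and a saturated chain carbon lie within the scatter of one another. Nothing available offers a reason for this flat reading.

The compounds shown leave open whether any group at this place can shift the dose in this assay at all, as none of their steps goes beyond the scatter. A carboxylic acid or a primary amine on that same saturated chain carbon would show whether this level holds for groups other than the three seen so far.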